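Swapping the aryl group on one enone arm

A few compounds are considered here, and "the series" means these few. Any claim that something is new, unique, unknown or untested is made for them only; others in the source may bear on it.

Measured compounds:
compound 1, `COc1cccc(/C=C2\CCC/C(=C\c3cc(OC)c(OC)c(OC)c3)C2=O)c1OC`, 4500 nM
compound 2, `COc1cc(/C=C2\CCC/C(=C\c3ccc(O)c(O)c3)C2=O)cc(OC)c1OC`, 3200 nM
compound 3, `COc1ccccc1/C=C1\CCC/C(=C\c2cc(OC)c(OC)c(OC)c2)C1=O`, 2000 nM

In a functional assay on SW-620 cells (Homo sapiens) for antiproliferative activity, read by MTT assay, with a stated time of 72 h (a lower number here means a stronger inhibitor, a higher number a weaker inhibitor), compound 3 gives the lowest number of the three. Its nearest neighbour is compound 2, at a gap that stays within the scatter (a 1.6-fold lower number from compound 2 to compound 3 (0.20 log units; within the scatter)); only the gap to compound 1 passes beyond it (a 2.3-fold lower number from compound 1 to compound 3 (0.35 log units; beyond the scatter)), and even that is modest. Between compound 1 and compound 2 the difference is also within the scatter (a 1.4-fold lower number from compound 1 to compound 2 (0.15 log units; within the scatter)).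

Compound 4, `COc1cc(/C=C2\CCC/C(=C\c3cccc(O)c3)C2=O)cc(OC)c1OC`, arises from compound 3 by the change (3-hydroxyphenyl in place of 2-methoxyphenyl on a double-bonded chain carbon bound to a double-bonded ring carbon). For the measured compounds named here, no measured step introduces a 3-hydroxyphenyl group, so the closest guides are the step from compound 2 to compound 3, where a 3,4-dihydroxyphenyl group gave way to 2-methoxyphenyl with little effect, and the step from compound 1 to compound 3, which was modest. Both suggest that aryl changes at this position move the number only a little, in either direction. The expected step for compound 4 is therefore small, a 1.3-fold higher number from compound 3 to compound 4 (0.10 log units; within the scatter), likely within the scatter. Compound 4 is estimated at 2500 nM in this assay, with a range from 1000 nM to 6000 nM.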

Compound 4, half-maximal inhibitory concentration: > 10000 nM
Compound 4 gave a limit, no number; the forecaster's own chance of this, stated with the estimate: 5%; at least 4.0-fold (0.60 log units) between middle value and limit.
By their numbers in this assay, from the lowest: compounds 3, 2 and 1 (each within the scatter of the next, the first and the last beyond it). At a limit, above all of these: compound 4.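

In this assay compound 4 gives a limit rather than a number, and this is the only such result among the compounds shown: the limit of > 10000 nM in this assay, at which 1 of the 4 values shown sits. For the compounds shown here, the earlier steps on this arm had stayed small, so this is the first sign that the aryl group at this place, on a double-bonded chain carbon bound to a double-bonded ring carbon, can matter sharply: 3-hydroxyphenyl in place of 2-methoxyphenyl gives an at least 5.0-fold higher number from compound 3 to compound 4 (0.69 log units; beyond the scatter), and 3-hydroxyphenyl in place of 2,3-dimethoxyphenyl gives an at least 2.2-fold higher number from compound 1 to compound 4 (0.34 log units; beyond the scatter). The loss of a single hydroxy from the 3,4-dihydroxyphenyl group also counts, giving an at least 3.1-fold higher number from compound 2 to compound 4 (0.49 log units; beyond the scatter), so compound 2 retains a measurable number while its closest relative does not.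

From the compounds shown here alone, the true size of all three steps stays unknown, as each ends at a limit, and these compounds cannot separate the effect of losing the methoxy groups from that of the lone hydroxy. Nor do they say whether another single group on this arm, such as the amine of a 3-aminophenyl or the carboxylic acid of a 3-carboxyphenyl, would keep a measurable number.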